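Aryl amine variation on a shared core, cell growth inhibition

The source may report more compounds than this note shows. Statements on the series, on what has been measured and on what is new or still open speak of the compounds shown alone.

Measured compounds:
compound 1, `COc1ccccc1Nc1nc(SCc2cn(CC(=O)NC(=O)Nc3ccccn3)nn2)nc(-c2ccc(C)cc2)c1C#N`, 7960 nM
compound 2, `Cc1ccc(Nc2nc(SCc3cn(CC(=O)NC(=O)Nc4ccccn4)nn3)nc(-c3ccc(C)cc3)c2C#N)cc1`, 9890 nM

In a functional assay on MGC-803 cells (Homo sapiens) for inhibition, read by MTT assay, with a stated time of 72 h (a higher number here means a weaker inhibitor, a lower number a stronger inhibitor), compound 1 gives 7960 nM and compound 2 gives 9890 nM. The two numbers lie within the scatter of each other: the step of a 1.2-fold higher number from compound 1 to compound 2 (0.09 log units; within the scatter) does not separate them, so compound 2 stands alongside compound 1 rather than apart from it, with the swap of the aryl group on the nitrogen leaving the read-out essentially unchanged.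

Compound 3, `Cc1ccc(-c2nc(SCc3cn(CC(=O)NC(=O)Nc4ccccn4)nn3)nc(Nc3cccc(C(F)(F)F)c3)c2C#N)cc1`, differs from compound 2 by 3-(trifluoromethyl)phenyl in place of 4-methylphenyl on a nitrogen on an aromatic ring. Going by the values given here, the only measured step that bears on this change is the one at the same nitrogen, a 1.2-fold higher number from compound 1 to compound 2 (0.09 log units; within the scatter), which stayed within the scatter. No other comparison in the set touches this part of the shared core. With the change again confined to the aryl group on that nitrogen, the expectation for compound 3 is no step beyond the scatter in this assay, that is a 1.1-fold lower number from compound 2 to compound 3 (0.04 log units; within the scatter). The estimate for compound 3 in this assay is therefore 9000 nM, with a range of 3000 nM to 27000 nM.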

Compound 3, half-maximal inhibitory concentration: 7580 nM
Compound 3: middle estimate off by 1.2-fold (0.07 log units), on the high side; the measured number falls inside the stated range.
By their numbers in this assay, from the lowest: compounds 3, 1 and 2 (each within the scatter of the next).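

Placing 3-(trifluoromethyl)phenyl on the nitrogen on an aromatic ring gives a 1.3-fold lower number from compound 2 to compound 3 (0.12 log units; within the scatter) in this assay and, against the 2-methoxyphenyl group, a 1.1-fold lower number from compound 1 to compound 3 (0.02 log units; within the scatter) in the same read-out. All three pairs now lie within the scatter, so the level reading at this nitrogen no longer rests on one pair: it holds for three phenyl groups that carry different substituents, including one with fluorine atoms, and no order can be drawn among them. Nothing at hand beyond these numbers bears on why the read-out stays level here.

As far as these compounds go, every group tested at this nitrogen is still a substituted phenyl ring, so it remains open whether a cyclohexyl group, a plain alkyl chain, or a phenyl ring bearing a carboxylic acid or an amine would move the number beyond the scatter. The flat result also says nothing about the rest of the shared core, since the 4-methylphenyl group on the core and the triazole-bearing side chain on sulfur are the same in all three compounds.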